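Shortening the alkyl tail on the aryl alkyne

A few compounds are considered here, and "the series" means these few. Any claim that something is new, unique, unknown or untested is made for them only; others in the source may bear on it.

Compound 1 `CCCCCCC#Cc1cn(C/C=C/CN2C(=O)c3ccccc3C2=O)c(=O)[nH]c1=O`: 28000 nM
Compound 2 `CCCCCCCCC#Cc1cn(C/C=C/CN2C(=O)c3ccccc3C2=O)c(=O)[nH]c1=O`: a limit, > 250000 nM
Compound 3 `CCCCCc1ccc(C#Cc2cn(C/C=C/CN3C(=O)c4ccccc4C3=O)c(=O)[nH]c2=O)cc1`: 23000 nM

In a functional assay on CCRF-CEM cells (Homo sapiens) for antiproliferative activity, read by MTT assay, with a stated time of 3 days (on this read-out lower numbers stand for stronger inhibition and higher numbers for weaker inhibition), compound 3 gives 23000 nM, the lowest of the two numbers available, with compound 1 nearest; the step of a 1.2-fold lower number from compound 1 to compound 3 (0.09 log units; within the scatter) lies within the scatter. For compound 2 the assay reports only a limit of > 250000 nM in this assay, at which 1 of the 3 values shown sits, rather than a number.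

Compound 4 `CCCCc1ccc(C#Cc2cn(C/C=C/CN3C(=O)c4ccccc4C3=O)c(=O)[nH]c2=O)cc1` differs from compound 3 by hydrogen in place of methyl on a saturated chain carbon, four bonds along the chain from an aromatic carbon. Going by the values given here, two measured steps bear on it. Adding carbons to the chain, an at least 8.9-fold higher number from compound 1 to compound 2 (0.95 log units; beyond the scatter), cost potency by at least a modest amount, and moving from that longer chain to the aryl tail, an at least 10-fold lower number from compound 2 to compound 3 (1.03 log units; beyond the scatter), recovered it. The present change removes a single carbon from a tail whose neighbour compound 1 already sits within the scatter of compound 3. The step of a 1.1-fold higher number from compound 3 to compound 4 (0.04 log units; within the scatter) is therefore expected to stay within the scatter, in either direction. For compound 4 the estimated value in this assay is 25000 nM, with a range from 8000 nM to 80000 nM.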

Compound 4, half-maximal inhibitory concentration: 31000 nM
The estimate for compound 4 lay 1.2-fold (0.09 log units) below the measured number; low and high end bracket the measured number.
By their numbers in this assay, from the lowest: compounds 3, 1 and 4 (each within the scatter of the next). At a limit, above all of these: compound 2.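

In this assay, the change from 4-pentylphenyl to 4-butylphenyl is the only step shown within the aryl tail, and a 1.3-fold higher number from compound 3 to compound 4 (0.13 log units; within the scatter) does not leave the scatter; against the hexyl compound, a 1.1-fold higher number from compound 1 to compound 4 (0.04 log units; within the scatter) also stays within it, so the shorter aryl tail still reads the same as hexyl on the triple-bonded carbon. Against the octyl compound, an at least 8.0-fold lower number from compound 2 to compound 4 (0.90 log units; beyond the scatter) lies beyond the scatter, as the step to compound 3 did, so removing this one carbon does not close that gap. Compound 2 is held at a limit rather than a number: the limit of > 250000 nM in this assay, at which 1 of the 4 values shown sits.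

The compounds shown leave open how far the tail can shrink, with propyl, ethyl or methyl in its place. They also leave open whether an amine or a carboxylic acid at the end of the chain would shift the number.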